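The source may report more compounds than this note shows. Statements on the series, on what has been measured and on what is new or still open speak of the compounds shown alone.

Going by the values given here, in an ADME assay on microsomes (Mus musculus) for metabolic stability (on this read-out lower numbers stand for slow clearance and higher numbers for fast clearance), compound 1 (`CNC(=O)[C@@H]1CCCN1S(=O)(=O)c1ccc(Cl)c(COc2cccc3c(C(F)(F)F)cc(C)nc23)c1Cl`) gives 1380 mL/min/kg and compound 2 (`Cc1cc(C(F)(F)F)c2cccc(OCc3c(Cl)ccc(S(=O)(=O)N4CCC(CCO)CC4)c3Cl)c2n1`) gives 1080 mL/min/kg, so compound 2 sits within the scatter of the only other measured compound. Compound 3 (`Cc1cc(C(F)(F)F)c2cccc(OCc3c(Cl)ccc(S(=O)(=O)N4C[C@@H](C)O[C@@H](C)C4)c3Cl)c2n1`) carries 2,6-dimethylmorpholin-4-yl in place of 4-(2-hydroxyethyl)piperidin-1-yl on a sulfonyl sulfur. Among the compounds with values here, the one measured step at this place, a 1.3-fold lower number from compound 1 to compound 2 (0.11 log units; within the scatter), stays within the scatter, so no step beyond the scatter is expected in this assay. The expected step is a 1.0-fold higher number from compound 2 to compound 3 (0.01 log units; within the scatter). For compound 3 the estimate is 1100 mL/min/kg, with an expected range of 550 mL/min/kg to 2100 mL/min/kg.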

Compound 3, clearance: 933 mL/min/kg
The estimate for compound 3 lay 1.2-fold (0.07 log units) above the measured number; the measured number falls inside the stated range.
By their numbers in this assay, from the lowest: compounds 3, 2 and 1 (each within the scatter of the next).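

In this assay, 2,6-dimethylmorpholin-4-yl in place of 4-(2-hydroxyethyl)piperidin-1-yl gives a 1.2-fold lower number from compound 2 to compound 3 (0.06 log units; within the scatter), and in place of 2-(methylcarbamoyl)pyrrolidin-1-yl it gives a 1.5-fold lower number from compound 1 to compound 3 (0.17 log units; within the scatter). All three groups on the sulfonyl sulfur now lie within the scatter of one another, and this holds for an entering group with 0 hydrogen-bond donors and 2 defined stereocentres. No measurement at hand bears on why the number stays within the scatter at this position. Still open, as far as these compounds go, is whether a carboxylic acid or a primary amine on the sulfonyl sulfur would move the number beyond the scatter. Equally open, from the compounds shown here alone, is whether a change in the shared core would do so.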